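Swapping the aryl group on the piperazine of compound 2

A few compounds are considered here, and "the series" means these few. Any claim that something is new, unique, unknown or untested is made for them only; others in the source may bear on it.

Compound 2 `CCCc1nc(-c2ccccc2)c(CNCCN2CCN(c3cccc(C)c3)CC2)o1` was tested in an assay on HEK293 cells for inhibition of Voltage-dependent T-type calcium channel subunit alpha-1G (Homo sapiens), read by fluorescence, tested at 10 uM (a higher number here means more inhibition at the concentration tested (going by the name of the read-out), a lower number less inhibition), where compound 2 gives 43.1%. That is the lowest of the three numbers in hand. Compound 1 `CCCc1nc(-c2ccccc2)c(CNCCN2CCN(c3ccc(Cl)cc3)CC2)o1` gives 55.8%, and compound 3 `CCCc1nc(-c2ccccc2)c(CNCCCN2CCN(c3ccc(F)cc3)CC2)o1` gives 62.5%; both stand above compound 2 by more than the scatter.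

The new compound 4 `CCCc1nc(-c2ccccc2)c(CNCCN2CCN(c3ccc(F)cc3)CC2)o1` differs from compound 2 in one place: 4-fluorophenyl in place of 3-methylphenyl on an amine nitrogen in a ring. One measured step speaks to this change. Going the other way, from a 4-chlorophenyl to the 3-methylphenyl, gave a number 12.7 percentage points lower from compound 1 to compound 2 (beyond the scatter). Within the data shown here, a 4-fluorophenyl is not a 4-chlorophenyl, so that step is only a rough guide; compound 3, which also carries a 4-fluorophenyl, sits at the highest of the three numbers, but no single-change step links it to compound 4.

On that basis the expected step of a number 9.9 percentage points higher from compound 2 to compound 4 (within the scatter) is a modest rise, roughly undoing the drop seen from compound 1 to compound 2. Compound 4 is therefore estimated at 53%, with a likely range from 40% to 66%.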

Compound 4, a percentage reported as inhibition, at one concentration (the size of the read-out at that concentration, not a potency): 54.1%
Compound 4: the middle estimate sits 1.1 percentage points below what was measured; low and high end bracket the measured number.
By their numbers in this assay, from the lowest: compound 2; then compounds 4, 1 and 3 (each within the scatter of the next).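

Two different groups at this place on the piperazine now stand clear of the 3-methylphenyl: the 4-chlorophenyl of compound 1 and the 4-fluorophenyl of compound 4, which in this assay gives a number 11 percentage points higher from compound 2 to compound 4 (beyond the scatter) as a second measured step. Exchanging the halogen on the ring gives a number 1.7 percentage points lower from compound 1 to compound 4 (within the scatter) and so leaves compound 1 and compound 4 indistinguishable here, which means that fluoro and chloro cannot be told apart in this setting. No measurement at hand explains why the 3-methylphenyl compound stands apart from these two.

The 3-methylphenyl differs from both halogen-bearing groups in the substituent and in its ring position, so these two features remain tangled. A 4-methylphenyl or a 3-chlorophenyl on the same nitrogen would separate them, and an unsubstituted phenyl would show what either substituent adds.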